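One added methyl on a nearly inactive compound

The compounds below may be only part of what the source reports. "The series", "measured", "known", "first", "only" and "open" are said of these compounds alone.

Compound 1 `COc1cccc(Nc2nc(-n3cc(C)nc3C)cs2)c1`: 60000 nM
Compound 2 `Cc1nccn1-c1csc(Nc2cccc(Br)c2)n1`: > 100000 nM (a limit, not a number)

Among the compounds with values here, in a functional assay on RKO cells (Homo sapiens) for cytotoxicity, read by resazurin assay, with a stated time of 72 h (on this read-out lower numbers stand for stronger inhibition and higher numbers for weaker inhibition), compound 1 gives 60000 nM, the only exact number so far. Compound 2 stands at a limit of this assay, with > 100000 nM recorded. That value is a limit and not a number.

Compound 3 `Cc1cn(-c2csc(Nc3cccc(Br)c3)n2)c(C)n1` differs from compound 2 in one place, with methyl in place of hydrogen on an aromatic carbon. Within the data shown here, no measured pair shows this change alone, so the expectation rests on very little. A small move toward stronger inhibition is expected, and it may not exceed the usual scatter. The estimated step is an at least 1.4-fold lower number from compound 2 to compound 3 (0.15 log units; that floor lies within the scatter). Compound 3 is expected at about 70000 nM. The estimated range for compound 3 runs from 30000 nM to 150000 nM, and the assay may again report only a limit.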

Compound 3, half-maximal inhibitory concentration: > 100000 nM
Compound 3 was reported as a limit (the forecaster's own chance of this, stated with the estimate: 40%); middle value at least 1.4-fold (0.15 log units) from the limit.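

In this assay, compound 3 is reported only as a limit, not a number, so adding this methyl to the five-membered ring does not lift the bromo series to a value that can be measured. The methyl step itself cannot be read because both compounds in it sit at the limit: the limit of > 100000 nM in this assay, at which 2 of the 3 values shown sit.

Compound 3 does add one new comparison, since bromo in place of methoxy on the aromatic carbon gives an at least 1.6-fold higher number from compound 1 to compound 3 (0.22 log units; that floor lies within the scatter). As far as these compounds go, what an amine or a longer chain on this same ring carbon would do to the bromo compounds stays open. So does the size of the methyl step in a compound that carries methoxy, such as compound 1, where a limit might not hide it.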